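The source may report more compounds than this note shows. Statements on the series, on what has been measured and on what is new or still open speak of the compounds shown alone.

Measured in a functional assay on brain (Rattus norvegicus, strain Wistar) for inhibition (a higher number here means a weaker inhibitor, a lower number a stronger inhibitor), so far
compound 1 `CCCCc1ccc(-c2c(C)[nH]c(=O)n2C(C)C)cc1` gives 10700 nM
compound 2 `CCCCc1ccc(-c2c(C)[nH]c(=O)n2CCCC)cc1` gives 12000 nM
compound 3 `Cc1[nH]c(=O)n(C2CCCCC2)c1-c1ccccc1` gives 47600 nM

Compound 3 has the highest number of the three, and its gaps to compound 1 and to compound 2 both lie beyond the scatter. Compound 4 `CCCCc1ccc(-c2c(C)[nH]c(=O)n2C2CCCCC2)cc1` comes from compound 3 by one change, butyl in place of hydrogen on an aromatic carbon.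

Going by the values given here, no measured step makes this change on its own. Among the compounds with values here, the one measured step, butyl in place of isopropyl on an aromatic nitrogen, is a 1.1-fold higher number from compound 1 to compound 2 (0.05 log units; within the scatter) and so gives no shift to build on. The closest guide is indirect. Compound 1 and compound 2 already carry the butyl that compound 4 gains, with compound 1 at 10700 nM and compound 2 at 12000 nM in this series. The group on nitrogen in compound 4 is that of compound 3, however, so the comparison is not clean.

A move to a lower number, near the level of those two compounds, is expected in this assay for this change. The expected step is a 3.7-fold lower number from compound 3 to compound 4 (0.56 log units; beyond the scatter) as estimated here. For compound 4 the estimated value is 13000 nM with 5000 nM to 32000 nM as the expected range.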

Compound 4, half-maximal inhibitory concentration: 27100 nM
Compound 4: middle estimate off by 2.1-fold (0.32 log units), on the low side; low and high end bracket the measured number.
By their numbers in this assay, from the lowest: compounds 1 and 2 (each within the scatter of the next); then compounds 4 and 3 (each within the scatter of the next).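

In this assay butyl in place of hydrogen on an aromatic carbon, para to a large group, gives a 1.8-fold lower number from compound 3 to compound 4 (0.24 log units; within the scatter) and so, with cyclohexyl on the aromatic nitrogen, this change produces no shift that can be told from the scatter. With the butyl kept on the six-membered aromatic ring, the group on the aromatic nitrogen now shows an effect on the number that the earlier pair, at a 1.1-fold higher number from compound 1 to compound 2 (0.05 log units; within the scatter), did not show: cyclohexyl in place of butyl gives a 2.3-fold higher number from compound 2 to compound 4 (0.35 log units; beyond the scatter) and cyclohexyl in place of isopropyl gives a 2.5-fold higher number from compound 1 to compound 4 (0.40 log units; beyond the scatter), both modest but beyond the scatter. Nothing available here gives a reason for either of these results.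

The compounds shown leave open whether the butyl change would read the same with isopropyl or butyl on the aromatic nitrogen instead of cyclohexyl. They also leave open whether a longer chain, an amine or a carboxylic acid on that aromatic carbon would move the number beyond the scatter.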